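A few compounds are considered here, and "the series" means these few. Any claim that something is new, unique, unknown or untested is made for them only; others in the source may bear on it.

Of the compounds shown here, three have been measured in a functional assay on FM3A cells (Homo sapiens) for inhibition, with FM3A (Mus musculus) as the target; on this read-out higher numbers stand for weaker inhibition and lower numbers for stronger inhibition. Compound 1, `CC(=O)OC(C)n1cnc2c(Cl)nc(N)nc21`, gives in this assay a result that is a limit of the assay rather than a number, > 500000 nM. Compound 2, `CC(=O)OC(C)n1cnc2c(Cl)nc(F)nc21`, gives in this assay 93000 nM. From the compounds shown here alone, the change between them is fluoro in place of amino on an aromatic carbon, and it brought an at least 5.3-fold lower number from compound 1 to compound 2 (0.73 log units; beyond the scatter); how far that step really reaches stays open because compound 1 sits at the limit of > 500000 nM in this assay, at which 1 of the 3 values shown sits.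

Compound 3, `CC(=O)OCCOn1cnc2c(S)nc(N)nc21`, carries a different core; the difference between its core and that of compound 1 is not broken down here. In this assay compound 3 gives 2000 nM, which stands well below the number of compound 2.

Compound 4, `CC(=O)OCCOn1cnc2c(S)nc(F)nc21`, has not yet been measured in this assay. It differs from compound 3 by fluoro in place of amino on an aromatic carbon. Among the compounds with values here, this is the same kind of change as the one from compound 1 to compound 2, but not the same: in compound 1 the place is meta to a chloro group, while in compound 3 it is meta to a sulfanyl group.

Within the data shown here, the only guide is the step of an at least 5.3-fold lower number from compound 1 to compound 2 (0.73 log units; beyond the scatter), and on that basis the step from compound 3 to compound 4 is expected to be of a similar, modest size, a 4.0-fold lower number from compound 3 to compound 4 (0.60 log units; beyond the scatter). Compound 4 is therefore estimated at 500 nM, with the expected range running from 150 nM to 2000 nM.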

Compound 4, half-maximal inhibitory concentration: 136000 nM
For compound 4 the middle estimate is 270-fold (2.43 log units) below the measured one; the whole stated range lies below it.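

On the core of compound 3, fluoro in place of amino on an aromatic carbon gives a 68-fold higher number from compound 3 to compound 4 (1.83 log units; beyond the scatter) in this assay, so the weaker inhibition here runs opposite to the stronger inhibition seen with the same change on the core of compound 1. Even the direction of this change therefore does not carry from one core to the other, and a step read on one core is a poor guide to the same step on the other: the same change on two cores in this assay, an at least 5.3-fold lower number (0.73 log units; beyond the scatter) from compound 1 to compound 2 and a 68-fold higher number (1.83 log units; beyond the scatter) from compound 3 to compound 4, at least 360-fold (2.56 log units) apart, beyond the scatter of two such steps

Compound 1 gives a limit of the assay rather than a number, so the first step and the gap between the two steps have no fixed size, and the pairs show that the outcome depends on the core but not which difference between the cores is responsible: the limit of > 500000 nM in this assay, at which 1 of the 4 values shown sits.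

Within the data shown here, with only two pairs, it stays open how the change behaves on any further core, and how another group in the same place, such as methylamino or methoxy, would compare with amino and fluoro. From the compounds shown here alone, it also stays open whether the reversal goes with the sulfanyl group, with the chloro group it replaces, or with the different side chain.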